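Limits only: an aryl swap at compound 3

This account rests on a few compounds, and the source may have more. Where it says the series, first, only, none or still open, it means among the compounds named here.

Measured in a functional assay on Vero cells (Chlorocebus sabaeus) for inhibition (a higher number here means a weaker inhibitor, a lower number a stronger inhibitor), all three results being limits:
Compound 1 `Clc1ccc(Cn2cnc3c(-c4ccco4)ncnc32)cc1Cl`: > 10 ug/mL
Compound 2 `Fc1ccccc1Cn1cnc2c(-c3ccco3)ncnc21`: > 10 ug/mL
Compound 3 `Clc1nc(-c2ccco2)c2ncn(Cc3ccc(Cl)c(Cl)c3)c2n1`: > 10 ug/mL

Compound 3 has no numerical value in this assay. Its result of > 10 ug/mL is a limit. Compound 1 and compound 2 stand at that same limit, so the series offers no number to rank against, as the limit of > 10 ug/mL in this assay, at which 3 of the 3 values shown sit, shows.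

Compound 4 `COc1cccc(Cn2cnc3c(-c4ccco4)nc(Cl)nc32)c1` keeps the chloro-bearing core of compound 3 and carries 3-methoxyphenyl in place of 3,4-dichlorophenyl on a saturated chain carbon bound to an aromatic nitrogen.

Among the compounds with values here, only one measured step lies close to this change, and it concerns a different place in the structure. That step, a step that the two limits leave unreadable from compound 1 to compound 3, has no readable size. Within the data shown here, no measured step covers the exchange of the aryl group itself. The expectation therefore rests on (the limit of > 10 ug/mL in this assay, at which 3 of the 3 values shown sit), and no direction can be drawn from it. No step beyond the scatter is expected in this assay, and a further limit is the most likely result.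

The estimated step is a step that the limit leaves unreadable from compound 3 to compound 4. For compound 4 the expected value is 12 ug/mL, with an estimated range from 5 ug/mL to 30 ug/mL.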

Compound 4, half-maximal inhibitory concentration: > 10 ug/mL
Compound 4 was reported as a limit; the forecaster's own chance of this, stated with the estimate: 75%; the middle value does not contradict the limit.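

In this assay compound 4 gives > 10 ug/mL, which is a limit, and compound 3 also stands at a limit, so no step can be read between them. The compounds shown leave open whether 3-methoxyphenyl in place of 3,4-dichlorophenyl changes inhibition at all, and no ranking is possible: the limit of > 10 ug/mL in this assay, at which 4 of the 4 values shown sit.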